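Trifluoromethyl in place of iodo on the aryl ring

The source may report more compounds than this note shows. Statements on the series, on what has been measured and on what is new or still open speak of the compounds shown alone.

Compound 3 `COc1cc(C(=O)c2sc(-c3ccc(I)cc3)cc2N)cc(OC)c1OC` is one of three close relatives measured in a functional assay on L1210 cells (Mus musculus) for antiproliferative activity; on this read-out higher numbers stand for weaker inhibition and lower numbers for stronger inhibition. Compound 1 `COc1cc(C(=O)c2sc(-c3ccc(-c4ccccc4)cc3)cc2N)cc(OC)c1OC` carries a phenyl group at the varied position; in this assay compound 1 gives > 10000 nM, which is a limit of the assay and not a number. Compound 2 `COc1cc(C(=O)c2sc(-c3ccc([N+](=O)[O-])cc3)cc2N)cc(OC)c1OC` carries nitro there, and in this assay compound 2 gives 100 nM. Among the compounds with values here, compound 3 carries iodo, and in this assay compound 3 gives 400 nM, the higher of the two numbers known; the only other number lies lower, with a 4.0-fold higher number from compound 2 to compound 3 (0.60 log units; beyond the scatter). Against the phenyl compound both groups give far lower numbers: an at least 100-fold lower number from compound 1 to compound 2 (2.00 log units; beyond the scatter) and an at least 25-fold lower number from compound 1 to compound 3 (1.39 log units; beyond the scatter).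

Compound 4 `COc1cc(C(=O)c2sc(-c3ccc(C(F)(F)F)cc3)cc2N)cc(OC)c1OC` has not yet been measured. It differs from compound 3 in one place: trifluoromethyl in place of iodo on an aromatic carbon. Within the data shown here, the steps that bear on this are the two large ones from compound 1, where the phenyl group leaves, and the modest one between nitro and iodo. Trifluoromethyl, like nitro and iodo, brings no ring, so the number is expected to stay far from the limit of compound 1. For compound 4 a step of a 1.3-fold lower number from compound 3 to compound 4 (0.12 log units; within the scatter) is expected, within the scatter or barely beyond it. Compound 4 is therefore estimated at 300 nM, between 100 nM and 1000 nM.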

Compound 4, half-maximal inhibitory concentration: 370 nM
The estimate for compound 4 lay 1.2-fold (0.09 log units) below the measured number, within the range that was stated.
By their numbers in this assay, from the lowest: compound 2; then compounds 4 and 3 (each within the scatter of the next). At a limit, above all of these: compound 1.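

In this assay, changing 4-iodophenyl to 4-(trifluoromethyl)phenyl leaves the number within the scatter (a 1.1-fold lower number from compound 3 to compound 4 (0.03 log units; within the scatter)), so at this position the two groups cannot be told apart, even though trifluoromethyl brings more heavy atoms than iodo. Nitro now stands apart from two groups instead of one, with a step to trifluoromethyl (a 3.7-fold higher number from compound 2 to compound 4 (0.57 log units; beyond the scatter)) that is modest, as the step from nitro to iodo was. A third group without a ring also lies far from the phenyl compound (an at least 27-fold lower number from compound 1 to compound 4 (1.43 log units; beyond the scatter)), and that step can be read only as a bound, since compound 1 stands at a limit: the limit of > 10000 nM in this assay, at which 1 of the 4 values shown sits.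

The compounds shown do not tell whether the low number of compound 2 is particular to nitro or would be shared by other groups at this place, such as a nitrile, an amine or a carboxylic acid. They also leave open how large a group this position accepts before the number climbs towards that of compound 1, which a methyl, an ethyl or a longer chain, or a pyridine ring, could help to settle.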